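This account rests on a few compounds, and the source may have more. Where it says the series, first, only, none or still open, it means among the compounds named here.

Measured in a functional assay on K562 cells (Homo sapiens) for antiproliferative activity; a lower number here means a stronger inhibitor of growth, a higher number a weaker inhibitor of growth:
- compound 1 `COCCCCCCCCCCCCCCC/C=C1\CC(CO)(COC(=O)C(C)(C)C)OC1=O`: 0.189 ug/mL
- compound 2 `COC(=O)CCCCCCCCCCCCCC/C=C1\CC(CO)(COC(=O)C(C)(C)C)OC1=O`: 0.856 ug/mL
- compound 3 `CC(C)(C)C(=O)OCCCCCCCCCCCCCCC/C=C1\CC(CO)(COC(=O)C(C)(C)C)OC1=O`: 0.352 ug/mL
- compound 4 `CC(=O)NCCCCCCCCCCCCCCC/C=C1\CC(CO)(COC(=O)C(C)(C)C)OC1=O`: not yet measured

The numbers place compound 3 close to one neighbour and apart from the other: a 1.9-fold higher number from compound 1 to compound 3 (0.27 log units; within the scatter), while a 2.4-fold lower number from compound 2 to compound 3 (0.39 log units; beyond the scatter). Compound 4 carries acetamido in place of ((tert-butyl)carbonyl)oxy on a saturated chain carbon, ten or more bonds along the chain from a double-bonded chain carbon. Those two steps bear on this change, as does a 4.5-fold higher number from compound 1 to compound 2 (0.66 log units; beyond the scatter), the largest of the three and still modest. Going by the values given here, none of the measured compounds carries acetamido, so only a rough guide exists. A small rise within the scatter is expected, a 1.3-fold higher number from compound 3 to compound 4 (0.11 log units; within the scatter). For compound 4 the estimated value is 0.45 ug/mL, with an expected range of 0.15 ug/mL to 1.4 ug/mL.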

Compound 4, concentration for 50% growth inhibition: 3.38 ug/mL
Beside the measured number, compound 4's estimate is 7.5-fold (0.88 log units) below it, and the stated range ends below it.
By their numbers in this assay, from the lowest: compounds 1 and 3 (each within the scatter of the next); then compound 2; then compound 4.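

In this assay, going by these compounds alone, this chain end proves far less tolerant than the earlier compounds suggested: acetamido gives a 9.6-fold higher number from compound 3 to compound 4 (0.98 log units; beyond the scatter) and a 3.9-fold higher number from compound 2 to compound 4 (0.60 log units; beyond the scatter) as well as an 18-fold higher number from compound 1 to compound 4 (1.25 log units; beyond the scatter) and leaves compound 4 the weakest of the four. Unlike ((tert-butyl)carbonyl)oxy, acetamido carries a hydrogen-bond donor, so a nitrogen-linked end group with that donor can sit far from the other three here. No measurement shown explains the loss.

On these data alone, whether it follows from the amide as a whole or from its hydrogen remains open. A carboxylic acid, an amine or an N-methyl acetamide at this chain end would test that.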